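Swapping one aromatic ring group on compound 3

The source may report more compounds than this note shows. Statements on the series, on what has been measured and on what is new or still open speak of the compounds shown alone.

In an in vivo ADME assay on the whole organism (strain 129/SvEvBrd x C57BL/6) for pharmacokinetics, with Mus musculus as the target (on this read-out higher numbers stand for higher oral bioavailability and lower numbers for lower oral bioavailability), compound 3 `OC[C@@H](O)[C@@H](O)[C@H](O)c1c[nH]c(-c2cscn2)n1` gives 12% and lies within the scatter of compound 1 `CCc1[nH]c(C(C)=O)nc1[C@@H](O)[C@H](O)[C@H](O)CO` at 17.1% so the two stand level. Compound 2 `CC(=O)c1nc([C@@H](O)[C@H](O)[C@H](O)CO)c(-c2ccccc2)[nH]1` reaches 49.6% and stands beyond the scatter above both of them.

Among the compounds with values here, compound 4 `Cn1cnc(-c2nc([C@@H](O)[C@H](O)[C@H](O)CO)c[nH]2)c1` has no measurement yet. It differs from compound 3 in a single group, and the change is 1-methyl-1H-imidazol-4-yl in place of 1,3-thiazol-4-yl on an aromatic carbon with 1-methyl-1H-imidazol-4-yl in place of 1,3-thiazol-4-yl on an aromatic carbon. Each of these groups is one five-membered aromatic ring with 2 hetero atoms.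

Within the data shown here, the only measured step is a number 32.5 percentage points higher from compound 1 to compound 2 (beyond the scatter) and it is large, which shows that replacing one group can move this number a long way. Among the measured compounds shown here, that step puts phenyl in place of ethyl, however, and no measured step exchanges one five-membered aromatic ring for another. It therefore gives no firm size or direction for this swap, and no step beyond the scatter is expected. The expected change is a number 5 percentage points higher from compound 3 to compound 4 (within the scatter) in this assay and remains within the scatter. For compound 4 the estimated value is 17% with an expected range from 5% to 40% on this measure.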

Compound 4, oral bioavailability: 3%
Compound 4: the middle estimate sits 14 percentage points above what was measured; the measured number lies below the stated range.
By their numbers in this assay, from the lowest: compounds 4, 3 and 1 (each within the scatter of the next, the first and the last beyond it); then compound 2.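

Putting 1-methyl-1H-imidazol-4-yl in place of 1,3-thiazol-4-yl, on an aromatic carbon between two ring nitrogen atoms, gives in this assay a number 9 percentage points lower from compound 3 to compound 4 (within the scatter), so compound 3 and compound 4 stand level. Within the data shown here, this is the first measured exchange of one five-membered aromatic ring with 2 hetero atoms for another, and it shows that this particular swap, which trades a sulfur for a nitrogen and brings one more heavy atom while the counts of hydrogen-bond donors and acceptors stay the same, leaves the number within the usual scatter, unlike the large step of a number 32.5 percentage points higher from compound 1 to compound 2 (beyond the scatter) made elsewhere with a different pair of groups. Nothing measured here bears on what lies behind this result.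

The two rings differ in both the ring atoms and the methyl group, so these compounds cannot separate the effect of one from the other, and the plain 1H-imidazol-4-yl group, without the methyl, would be needed to do that. From the compounds shown here alone, it also remains open whether a group of a different kind at this position, such as an amine, a carboxylic acid or a longer chain, would move the number beyond the scatter.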